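This account rests on a few compounds, and the source may have more. Where it says the series, first, only, none or still open, it means among the compounds named here.

Of the compounds shown here, three have been measured in a functional assay on PC-3 cells (Homo sapiens) for inhibition, read by MTT assay, with a stated time of 48 h; a higher number here means a weaker inhibitor, a lower number a stronger inhibitor. Compound 1 `COc1cc(N(Cc2ccc(Br)cc2)S(=O)(=O)c2ccc(C)cc2)cc(OC)c1OC` gives 4680 nM in this assay, compound 2 `COc1cc(N(Cc2cccc(C)c2)S(=O)(=O)c2ccc(C)cc2)cc(OC)c1OC` gives 8580 nM, and compound 3 `Cc1ccc(S(=O)(=O)N(Cc2nc3ccccc3[nH]2)c2ccc(F)cc2)cc1` gives 45000 nM. The number for compound 3 is the highest of the three, and its gaps to compound 2 and to compound 1 both lie beyond the scatter, so on these numbers compound 3 is the weakest inhibitor of the set.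

Compound 4 `Cc1ccc(S(=O)(=O)N(Cc2nc3ccccc3[nH]2)c2ccc(Cl)cc2)cc1` keeps the core of compound 3 and carries the change (chloro in place of fluoro on an aromatic carbon). Among the compounds with values here, the only measured step, a 1.8-fold higher number from compound 1 to compound 2 (0.26 log units; within the scatter), concerns a different part of a different scaffold, the group on the saturated chain carbon bound to the sulfonamide nitrogen, and is itself within the scatter; no measured step alters a halogen on the aromatic ring in question. Within the data shown here, there is thus no step in this set that bears on the change, and the expectation for compound 4 is a step of no more than the scatter, a 1.1-fold lower number from compound 3 to compound 4 (0.05 log units; within the scatter). Compound 4 is therefore estimated at 40000 nM, with a range from 13000 nM to 120000 nM.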

Compound 4, half-maximal inhibitory concentration: 42200 nM
The estimate for compound 4 lay 1.1-fold (0.02 log units) below the measured number, and the stated range covers the measured number.
By their numbers in this assay, from the lowest: compounds 1 and 2 (each within the scatter of the next); then compounds 4 and 3 (each within the scatter of the next).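

In this assay, within the data shown here, the exchange of 4-fluorophenyl for 4-chlorophenyl gives the first measured step at this position, a 1.1-fold lower number from compound 3 to compound 4 (0.03 log units; within the scatter), and it is the first step to change a halogen on an aromatic carbon. On this core, with the halogen para to a large group, chloro in place of fluoro thus leaves the number within the scatter, so compound 3 and compound 4 cannot be told apart in this assay. No measurement here accounts for this result.

Going by these compounds, it remains open whether a group other than a halogen at this position, such as an amine or a carboxylic acid, would move the number beyond the scatter. On these data alone, it is also open whether the same exchange would read alike on the core of compound 1.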